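A few compounds are considered here, and "the series" means these few. Any claim that something is new, unique, unknown or untested is made for them only; others in the source may bear on it.

Working notes on the series, read in a functional assay on ECa-109 cells for inhibition, with ECa-109 cell line (Homo sapiens) as the target, read by sulforhodamine B assay; a lower number here means a stronger inhibitor, a higher number a weaker inhibitor. Compound 1 (`CCc1ccc(NC2=CC(=O)c3c(nc4n3[C@H]3OC[C@@H](O)[C@H]3OC4)C2=O)cc1`) gives > 4000 nM, which is a limit of the assay and not a number. Compound 2 (`CCOc1ccccc1NC1=CC(=O)c2c(nc3n2[C@H]2OC[C@@H](O)[C@H]2OC3)C1=O`) gives 4320 nM. Compound 3 (`O=C1C(Nc2cccc(Cl)c2)=CC(=O)c2c1nc1n2[C@H]2OC[C@@H](O)[C@H]2OC1`) gives 3080 nM. Compound 3 therefore has one close neighbour among the true numbers, and the gap is a 1.4-fold lower number from compound 2 to compound 3 (0.15 log units; within the scatter). Against the limit, the comparison reads an at least 1.2-fold lower number from compound 1 to compound 3 (0.11 log units; that floor lies within the scatter), and the remaining pair gives a step that the limit leaves unreadable from compound 1 to compound 2.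

Compound 4 (`O=C1C(Nc2cccc(F)c2)=CC(=O)c2c1nc1n2[C@H]2OC[C@@H](O)[C@H]2OC1`) differs from compound 3 at one place: fluoro in place of chloro on an aromatic carbon, with fluoro in place of chloro on an aromatic carbon, meta to a large group. Within the data shown here, no measured step makes this exchange. The nearest evidence is the change of the substituted phenyl on the amine nitrogen, and its only readable size is a 1.4-fold lower number from compound 2 to compound 3 (0.15 log units; within the scatter). On that basis, the expected change in this assay is no larger than the scatter, in either direction, and is estimated as a 1.1-fold higher number from compound 3 to compound 4 (0.04 log units; within the scatter). For compound 4 the estimated value is 3400 nM, with an expected range of 1600 nM to 7000 nM.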

Compound 4, half-maximal inhibitory concentration: 2370 nM
Estimate against measurement, compound 4: 1.4-fold (0.16 log units) above; the measured number falls inside the stated range.
By their numbers in this assay, from the lowest: compounds 4, 3 and 2 (each within the scatter of the next).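

In this assay, the exchange on this aromatic carbon, meta to a large group, now has a direct reading: a 1.3-fold lower number from compound 3 to compound 4 (0.11 log units; within the scatter). Chloro and fluoro at this place therefore cannot be told apart here, and the 3-fluorophenyl compound also stays within the scatter of the 2-ethoxyphenyl compound, with a 1.8-fold lower number from compound 2 to compound 4 (0.26 log units; within the scatter). Against compound 1, whose value is a limit and not a number, the reading is an at least 1.6-fold lower number from compound 1 to compound 4 (0.22 log units; that floor lies within the scatter): the limit of > 4000 nM in this assay, at which 1 of the 4 values shown sits.

Among these compounds, whether a methoxy, trifluoromethyl, nitrile or amine group on the same carbon would give a step beyond the scatter stays open, as every readable step so far lies within it. Also open, on these data alone, is what a change on the shared core would do, such as a methoxy group in place of the free hydroxyl.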